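A few compounds are considered here, and "the series" means these few. Any claim that something is new, unique, unknown or untested is made for them only; others in the source may bear on it.

The series shares one core, carried by compound 1 `CC1=C(C(C)C(=O)NCCN(C)C)c2cc(F)ccc2/C1=C\c1ccc([S+](C)[O-])cc1`, compound 2 `CC1=C(C(C)C(=O)N(C)CCN(C)C)c2cc(F)ccc2/C1=C\c1ccc([S+](C)[O-])cc1` and compound 3 `CC1=C(C(C)C(=O)N(CCNC(C)C)C(C)C)c2cc(F)ccc2/C1=C\c1ccc([S+](C)[O-])cc1`, which differ only in the substituent on the amide carbonyl. In a functional assay on PC-3 cells (Homo sapiens) for inhibition, read by CellTiter-Glo, with a stated time of 72 h (a lower number here means that less compound is tolerated, a higher number that more compound is tolerated), compound 1 gives > 50000 nM, a limit of the assay rather than a number. In this assay compound 2 gives 44600 nM and compound 3 gives 15200 nM, so compound 3 holds the lowest of the two numbers. The step of an at least 1.1-fold lower number from compound 1 to compound 2 (0.04 log units; that floor lies within the scatter) stays within the scatter, whereas an at least 3.2-fold lower number from compound 1 to compound 3 (0.51 log units; beyond the scatter) and a 2.9-fold lower number from compound 2 to compound 3 (0.47 log units; beyond the scatter) both lie beyond it. Compound 4 `CC1=C(C(C)C(=O)NCCN2CCNCC2)c2cc(F)ccc2/C1=C\c1ccc([S+](C)[O-])cc1` differs from compound 3 by (2-(piperazin-1-yl)ethyl)amino in place of isopropyl(2-(isopropylamino)ethyl)amino on a carbonyl carbon, restoring the hydrogen on the amide-type nitrogen found in compound 1. Compound 4 is therefore expected to move back toward a higher number, a step of a 2.3-fold higher number from compound 3 to compound 4 (0.36 log units; beyond the scatter). Compound 4 is estimated at 35000 nM, between 14000 nM and 90000 nM.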

Compound 4, half-maximal cytotoxic concentration: > 50000 nM
Compound 4: no number, only a limit (the forecaster's own chance of this, stated with the estimate: 35%); middle value at least 1.4-fold (0.15 log units) away from the limit.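

At the carbonyl carbon, (2-(piperazin-1-yl)ethyl)amino in place of isopropyl(2-(isopropylamino)ethyl)amino gives an at least 3.2-fold higher number from compound 3 to compound 4 (0.51 log units; beyond the scatter), so the lower number of compound 3 does not carry over to this ring-bearing chain. The other readable step is an at least 1.1-fold higher number from compound 2 to compound 4 (0.04 log units; that floor lies within the scatter), a floor that does not exceed the scatter. Compound 4 gives only a limit, shared with compound 1, and the step between them cannot be read: the limit of > 50000 nM in this assay, at which 2 of the 4 values shown sit.

Still open, from the compounds shown here alone, is whether the isopropyl on the amide nitrogen or the terminal isopropylamino sets the number of compound 3. Going by these compounds, how a morpholine at the chain end or a longer chain would read in this assay also remains open.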